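Removing the piperidine from an anilide: effect on cell tolerance

A few compounds are considered here, and "the series" means these few. Any claim that something is new, unique, unknown or untested is made for them only; others in the source may bear on it.

compound 1 `O=C(CN1CCCCC1)Nc1ccc(-c2nc3cc(Cl)c(Cl)cc3[nH]2)cc1` — 54000 nM
compound 2 `O=C(CN1CCCCC1)Nc1ccc(-c2nc3ccccc3[nH]2)cc1` — 31000 nM

Both compounds were tested in an ADME assay on MT4 cells (Homo sapiens) for cytotoxicity, read by MTT assay, with a stated time of 96 h; a higher number here means that more compound is tolerated, a lower number that less compound is tolerated. Compound 1 gives the highest of the two numbers, but its nearest neighbour, compound 2, sits within the scatter of it, so the two cannot be told apart in this assay.

Compound 3 `CC(=O)Nc1ccc(-c2nc3cc(Cl)c(Cl)cc3[nH]2)cc1` has not yet been measured. It differs from compound 1 by a single change: hydrogen in place of piperidin-1-yl on a saturated chain carbon bound to a carbonyl carbon. Put plainly, the piperidine ring on the chain is gone and a plain acetyl group remains.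

Among the compounds with values here, no step between two measured compounds tells how such a change plays out here. The expectation for the step from compound 1 to compound 3 in this assay is therefore a small one, leaning upward, and it may well stay within the scatter, a 1.5-fold higher number from compound 1 to compound 3 (0.17 log units; within the scatter). On that basis compound 3 is estimated at 80000 nM, somewhere between 30000 nM and 200000 nM.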

Compound 3, half-maximal cytotoxic concentration: > 100000 nM
Compound 3: no number, only a limit; the forecaster's own chance of this, stated with the estimate: 25%; middle value at least 1.2-fold (0.09 log units) away from the limit.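

Compound 3 gives > 100000 nM in this assay, and this value is a limit of the assay, not a number. Putting hydrogen in place of piperidin-1-yl on a saturated chain carbon bound to a carbonyl carbon gives an at least 1.8-fold higher number from compound 1 to compound 3 (0.26 log units; that floor lies within the scatter), so the step cannot be told apart from the scatter as it stands. Still, this is the first reading of any change at this position, and it shows no sign that cells tolerate less of the compound once the piperidine ring is gone, though how far this reading can go is set by one fact: the limit of > 100000 nM in this assay, at which 1 of the 3 values shown sits.

The compounds shown leave open whether a small amine such as dimethylamino, or a carboxylic acid, on the same chain carbon would read like piperidin-1-yl or like hydrogen. A longer chain between the carbonyl and the piperidine ring is likewise untested here.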